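Replacing a Chlorophenyl Urea Arm with an Aryl Amide

This account rests on a few compounds, and the source may have more. Where it says the series, first, only, none or still open, it means among the compounds named here.

Of the compounds shown here, two have been measured. Compound 1 `COc1cc(Nc2ncnc3c(NC(=O)Nc4cccc(Cl)c4Cl)cccc23)cc(OC)c1` gives 63.2 nM in a functional assay on RT-112 cells (Homo sapiens) for antiproliferative activity, read by MTT assay, with a stated time of 72 h (on this read-out higher numbers stand for weaker inhibition of growth and lower numbers for stronger inhibition of growth), and compound 2 `COc1cc(Nc2ncnc3c(NC(=O)Nc4ccc(Cl)cc4)cccc23)cc(OC)c1` gives 2490 nM in this assay. Compound 2 therefore holds the highest of the two numbers, and the step of a 39-fold higher number from compound 1 to compound 2 (1.60 log units; beyond the scatter) is large and beyond the scatter, so this arm of the shared core clearly matters. Compound 3 `COc1cc(Nc2ncnc3c(NC(=O)c4cc(=O)c5ccccc5o4)cccc23)cc(OC)c1` differs from compound 2 in one place: a group of 11 heavy atoms (9 carbon, 2 oxygen; one six-membered aromatic ring of carbon only, one six-membered aromatic ring with 1 hetero atom) in place of a group of 8 heavy atoms (6 carbon, 1 nitrogen, 1 chlorine; one six-membered aromatic ring of carbon only), on a carbonyl carbon. Within the data shown here, no measured step covers this exact change; the only step to lean on is a 39-fold higher number from compound 1 to compound 2 (1.60 log units; beyond the scatter), which shows how strongly a change of the group on the carbonyl carbon can move the number. Because that step a 39-fold higher number from compound 1 to compound 2 (1.60 log units; beyond the scatter) is so large, a wide range is expected. Compound 3 is therefore expected to give about 800 nM, between 100 nM and 6000 nM. The expected step is a 3.1-fold lower number from compound 2 to compound 3 (0.49 log units; beyond the scatter).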

Compound 3, concentration for 50% growth inhibition: > 20000 nM
Compound 3 ended at the assay's limit; the forecaster's own chance of this, stated with the estimate: 5%; middle value at least 25-fold (1.39 log units) from the limit.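

Compound 3 stands at a limit of this assay and not at a number: the limit of > 20000 nM in this assay, at which 1 of the 3 values shown sits. Even so, replacing the (4-chlorophenyl)amino group brings an at least 8.0-fold higher number from compound 2 to compound 3 (0.90 log units; beyond the scatter), and the comparison with the dichlorophenyl compound brings an at least 310-fold higher number from compound 1 to compound 3 (2.50 log units; beyond the scatter). The earlier pair showed that this arm matters when both compounds keep an aryl group on an amide-type nitrogen; this result shows that a group joined directly to the carbonyl carbon, with a six-membered aromatic ring carrying a hetero atom, can take growth inhibition out of the range of the assay.

The change removes the nitrogen of the arm and alters the ring system together, so the compounds shown cannot separate these two parts of the change. A plain phenyl group on the carbonyl carbon would test the loss of that nitrogen alone.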